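A few compounds are considered here, and "the series" means these few. Any claim that something is new, unique, unknown or untested is made for them only; others in the source may bear on it.

Compound 1 `C[C@@H](CC(=O)O)NC(=O)CN1CCC[C@@H](CCC2CCNCC2)C1=O`: 7800 nM
Compound 2 `O=C(O)CCNC(=O)CNC(=O)CCCC1CCNCC1`: 8400 nM

In a functional assay with Homo sapiens as the target (on this read-out lower numbers stand for stronger inhibition and higher numbers for weaker inhibition), compound 1 gives 7800 nM and compound 2 gives 8400 nM. Within the data shown here, these two numbers lie within the scatter of each other, so compound 1 stands level with the only other compound measured. The two compounds differ in more than one place, so their values do not isolate the effect of any single structural change.

The next compound to consider is compound 3 `O=C(O)CCNC(=O)CN1CCC[C@@H](CCC2CCNCC2)C1=O`. It keeps the core of compound 1 but changes one small detail: hydrogen in place of methyl on a saturated chain carbon bound to an amide-type nitrogen and a saturated chain carbon. Put simply, it has hydrogen in place of methyl on a saturated chain carbon bound to an amide-type nitrogen and a saturated chain carbon, turning the 1-(carboxymethyl)ethyl group into 2-carboxyethyl.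

Among the measured compounds shown here, no measured pair shows this change directly. Compound 2 also carries the 2-carboxyethyl group and gives 8400 nM, so in this assay no step beyond the scatter is expected, in either direction. The expected change is a 1.2-fold higher number from compound 1 to compound 3 (0.06 log units; within the scatter). The estimated value for compound 3 is 9000 nM, within a range of 3000 nM to 27000 nM.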

Compound 3, half-maximal inhibitory concentration: 83 nM
The estimate for compound 3 lay 110-fold (2.04 log units) above the measured number; measured number outside the range, below it.
By their numbers in this assay, from the lowest: compound 3; then compounds 1 and 2 (each within the scatter of the next).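

In this assay, taking away the methyl on a saturated chain carbon bound to an amide-type nitrogen and a saturated chain carbon gives a 94-fold lower number from compound 1 to compound 3 (1.97 log units; beyond the scatter), a large step and the first one in this set that can be tied to a single place. It shows that this position is highly sensitive: the loss of one carbon atom, turning 1-(carboxymethyl)ethyl into 2-carboxyethyl, changes the number strongly, which compounds 1 and 2 could not reveal, as they differ in more than one place. No measurement here accounts for the size of this step, so its cause remains unknown.

As far as these compounds go, it remains open how an ethyl or hydroxymethyl group on this same carbon would compare with hydrogen and methyl, and whether a methyl with the opposite spatial arrangement would give a number like that of compound 1 or compound 3. From the compounds shown here alone, it is also open whether placing a methyl on the matching carbon of compound 2 would have a comparably large effect in a different structural setting.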